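Working notes: fluoro replaces cyclopentyloxy in compound 4

This account rests on a few compounds, and the source may have more. Where it says the series, first, only, none or still open, it means among the compounds named here.

Measured so far in an assay on CHO cells for antagonist activity at transient receptor potential cation channel subfamily V member 1 (Homo sapiens), read by FLIPR; on this read-out higher numbers stand for weaker inhibition and lower numbers for stronger inhibition:
- compound 1 `CC(C(=O)NCc1ccc(C(F)(F)F)cc1N1CCCCCCC1)c1ccc(NS(C)(=O)=O)c(F)c1` gives 2.8 nM
- compound 2 `CC(C)COc1cc(C(F)(F)F)ccc1CNC(=O)C(C)c1ccc(NS(C)(=O)=O)c(F)c1` gives 0.8 nM
- compound 3 `CC(C(=O)NCc1ccc(C(F)(F)F)cc1OC1CCCC1)c1ccc(NS(C)(=O)=O)c(F)c1` gives 0.6 nM

Among the compounds with values here, compound 3 has the lowest number of the three in this assay; its gap to compound 2 is within the scatter, and only the step from compound 1 stands beyond it. Compound 4 `CC(C(=O)NCc1ccc(C(F)(F)F)cc1F)c1ccc(NS(C)(=O)=O)c(F)c1` differs from compound 3 in one place: fluoro in place of cyclopentyloxy on an aromatic carbon.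

The measured steps all exchange one group of several atoms for another at this aromatic carbon: a 3.5-fold lower number from compound 1 to compound 2 (0.54 log units; beyond the scatter), a 4.7-fold lower number from compound 1 to compound 3 (0.67 log units; beyond the scatter), and a 1.3-fold lower number from compound 2 to compound 3 (0.12 log units; within the scatter). Within the data shown here, no measured step replaces such a group with a single atom. Among the measured compounds shown here, the change to compound 4 has no direct precedent here. What the steps do show is that the two oxygen-linked groups sit close together, while the eight-membered ring gives a higher number; the single fluoro lies outside that range.

Compound 4 is therefore estimated to give a higher number than compound 3 in this assay, a step of a 10-fold higher number from compound 3 to compound 4 (1.00 log units; beyond the scatter), with wide uncertainty. Compound 4 is expected at 6 nM, within 1.5 nM to 25 nM.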

Compound 4, inhibition constant: 68.7 nM
For compound 4 the middle estimate is 11-fold (1.06 log units) below the measured one; measured number above the stated range.
By their numbers in this assay, from the lowest: compounds 3 and 2 (each within the scatter of the next); then compound 1; then compound 4.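

In this assay, within the data shown here, the size of the group on this aromatic carbon, ortho to a large group, matters far more than the earlier compounds could show: fluoro in place of cyclopentyloxy gives a 110-fold higher number from compound 3 to compound 4 (2.06 log units; beyond the scatter), and fluoro in place of isobutoxy gives an 86-fold higher number from compound 2 to compound 4 (1.93 log units; beyond the scatter). Even the eight-membered ring, the least favourable of the earlier groups, compares well with the single fluorine atom, with a 25-fold higher number from compound 1 to compound 4 (1.39 log units; beyond the scatter), so all three larger groups give lower numbers than fluoro, and no compound shown goes against this. Nothing available explains this loss.

On these data alone, whether a methoxy or ethoxy group on this carbon would already recover the low numbers of compound 2 and compound 3 remains open. Also open, as far as these compounds go, is how a chloro group or a plain hydrogen would compare with fluoro here.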